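The compounds below may be only part of what the source reports. "The series", "measured", "known", "first", "only" and "open" are said of these compounds alone.

Working notes on the series.

Compound 1 `O/N=C(/Nc1cccc(Br)c1)c1ccc2occc2c1` is the reference point. In an assay on tissue (HeLa cells) for inhibition of Indoleamine 2,3-dioxygenase 1 (Homo sapiens), read by spectrophotometry (on this read-out lower numbers stand for stronger inhibition and higher numbers for weaker inhibition), compound 1 gives 1100 nM. Compound 2 `O/N=C(/Nc1ccc(F)c(Br)c1)c1ccc2occc2c1` gives 2600 nM in this assay, and the change from compound 1 to compound 2 is a fluoro in place of hydrogen on an aromatic carbon, with a 2.4-fold higher number from compound 1 to compound 2 (0.37 log units; beyond the scatter). Compound 3 `Cc1ccc(N/C(=N/O)c2ccc3occc3c2)cc1C` sits at the limit of > 30000 nM in this assay, at which 1 of the 3 values shown sits, so for compound 3 the result of > 30000 nM is a limit of the assay and not a number. Among the two numbers shown, compound 1 stands lowest, and compound 2 is its nearest neighbour.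

Compound 4 `CC1CCN(C(=O)c2cccc(N/C(=N/O)c3ccc4occc4c3)c2)CC1` is not yet measured. The change from compound 1 to compound 4 is (4-methylpiperidin-1-yl)carbonyl in place of bromo on an aromatic carbon. For the measured compounds named here, none of the measured steps makes this change: the one measured step, from compound 1 to compound 2, adds a fluoro elsewhere and leaves the bromo in place, and compound 3, which carries no bromo, returns only a limit. The bromo is therefore removed without a direct precedent, and the entering group is much larger than what leaves. The expectation is a weaker result, with the step from compound 1 to compound 4 estimated at a 4.5-fold higher number from compound 1 to compound 4 (0.66 log units; beyond the scatter). For compound 4 the value in this assay is estimated at 5000 nM, within a range from 1500 nM to 20000 nM.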

Compound 4, half-maximal inhibitory concentration: > 30000 nM
Compound 4: a limit, no number (the forecaster's own chance of this, stated with the estimate: 15%); middle value at least 6.0-fold (0.77 log units) away from the limit.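

In this assay compound 4 gives > 30000 nM, which is a limit of the assay and not a number. Replacing the bromo with (4-methylpiperidin-1-yl)carbonyl on this aromatic carbon gives an at least 27-fold higher number from compound 1 to compound 4 (1.43 log units; beyond the scatter), and this is the first step shown that changes the bromo itself, since the step to compound 2 adds a fluoro and leaves the bromo in place. This aromatic carbon is therefore sensitive to at least this one replacement, in which 9 heavy atoms, including a non-aromatic ring and a carbonyl, enter where 1 heavy atom leaves, and compound 4 adds to the values that give no number: the limit of > 30000 nM in this assay, at which 2 of the 4 values shown sit.

With only this one replacement at this aromatic carbon, the compounds shown cannot separate the effect of the piperidine ring from that of the carbonyl, nor say whether the bromo itself is needed. A chloro or methyl group on this carbon would test the smaller end of the range, and a primary amide would test the carbonyl without the 4-methylpiperidine ring.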